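Methoxy for fluoro on the aryl ring of a nitrone

A few compounds are considered here, and "the series" means these few. Any claim that something is new, unique, unknown or untested is made for them only; others in the source may bear on it.

Compound 3 `CC(C)(C)/[N+]([O-])=C/c1cn(-c2ccc(F)cc2)nn1` was tested in a functional assay on A549 cells (Homo sapiens) for inhibition, read by MTT assay, with a stated time of 24 h (on this read-out lower numbers stand for stronger inhibition and higher numbers for weaker inhibition), where compound 3 gives 87000 nM. Among the two numbers reported, compound 3 holds the higher one. Its nearest neighbour is compound 2 `CC(C)(C)/[N+]([O-])=C/c1cn(-c2ccccc2)nn1`, which in this assay gives 17400 nM. The step of a 5.0-fold higher number from compound 2 to compound 3 (0.70 log units; beyond the scatter) puts fluoro in place of hydrogen on the ring. Compound 1 `COc1ccc(-n2cc(/C=[N+](\[O-])Cc3ccccc3)nn2)cc1` carries a methoxy on its ring and a benzyl group on the nitrone nitrogen. In this assay compound 1 reaches only > 100000 nM, which is a limit of the assay and not a number (the limit of > 100000 nM in this assay, at which 1 of the 3 values shown sits).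

Compound 4 `COc1ccc(-n2cc(/C=[N+](\[O-])C(C)(C)C)nn2)cc1` differs from compound 3 by methoxy in place of fluoro on an aromatic carbon. Among the compounds with values here, the only measured step that bears on this change is a 5.0-fold higher number from compound 2 to compound 3 (0.70 log units; beyond the scatter), where a substituent entering that ring carbon weakened inhibition modestly. Compound 1 carries a methoxy but differs from compound 4 at the nitrone as well, so it gives no clean guide. The step from compound 3 to compound 4 is therefore expected to stay small, a 1.1-fold lower number from compound 3 to compound 4 (0.04 log units; within the scatter). Compound 4 is estimated at 80000 nM, expected between 30000 nM and 200000 nM.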

Compound 4, half-maximal inhibitory concentration: 23700 nM
Compound 4: the middle estimate sits 3.4-fold (0.53 log units) above what was measured; measured number below the stated range.
By their numbers in this assay, from the lowest: compounds 2 and 4 (each within the scatter of the next); then compound 3. At a limit, above all of these: compound 1.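

Methoxy and fluoro are not interchangeable on this aromatic carbon, para to a large group: in this assay the change gives a 3.7-fold lower number from compound 3 to compound 4 (0.56 log units; beyond the scatter), while methoxy in place of hydrogen gives a 1.4-fold higher number from compound 2 to compound 4 (0.13 log units; within the scatter), so a substituent entering here does not by itself weaken inhibition, as the fluoro step alone had suggested. With methoxy held on the ring, the group on the nitrone nitrogen also matters, since tert-butyl in place of benzyl gives an at least 4.2-fold lower number from compound 1 to compound 4 (0.62 log units; beyond the scatter). That step rests on compound 1, whose entry is a limit of the assay and not a number: the limit of > 100000 nM in this assay, at which 1 of the 4 values shown sits.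

Going by these compounds, whether an amine or a carboxylic acid on this ring carbon would follow methoxy or fluoro stays open. Also open, on these data alone, is whether the gap between methoxy and fluoro persists with benzyl on the nitrone nitrogen.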